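The source may hold more compounds than are shown below. What is called first, only, known or untested is meant among the compounds shown, and "the series" means these compounds.

Measured so far in a functional assay on HeLa cells (Homo sapiens) for antiproliferative activity, read by sulforhodamine B assay; on this read-out lower numbers stand for stronger inhibition and higher numbers for weaker inhibition:
compound 1 `C/C(=N\Nc1nc2ccccc2o1)c1cc(C)ncn1` gives 210 nM
compound 2 `CC/C(=N\Nc1nc2ccccc2o1)c1ccccn1` gives 52 nM
compound 3 `C/C(=N\Nc1nc2ccccc2o1)c1nccnc1C` gives 1860 nM

Compound 3 stands highest of the three numbers, beyond the scatter from compound 1, the nearest, and furthest from compound 2. Compound 4 `C/C(=N\Nc1nc2ccccc2o1)c1cnccn1` is not yet measured. It differs from compound 3 by hydrogen in place of methyl on an aromatic carbon, at the carbon next to the ring nitrogen and ortho to the large group. Going by the values given here, no measured pair with this single change exists, so the direction must be read from the set as a whole: the only compound with a six-membered ring bearing two nitrogens and no methyl ortho to the large group is compound 1, which gives the lower number. A moderate downward step in this assay is therefore expected, a 4.7-fold lower number from compound 3 to compound 4 (0.67 log units; beyond the scatter), taking compound 4 to an estimated 400 nM with a range from 120 nM to 1500 nM.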

Compound 4, half-maximal inhibitory concentration: 690 nM
Compound 4: the middle estimate sits 1.7-fold (0.24 log units) below what was measured, within the range that was stated.
By their numbers in this assay, from the lowest: compound 2; then compound 1; then compound 4; then compound 3.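

In this assay, hydrogen in place of methyl on an aromatic carbon, next to the ring nitrogen and ortho to a large group, gives a 2.7-fold lower number from compound 3 to compound 4 (0.43 log units; beyond the scatter). Going by these compounds alone, this is the first single-place comparison, and it shows that the methyl at this carbon is not required for activity and that the number is modestly lower without it. Nothing measured here accounts for the step.

As far as these compounds go, whether an ethyl chain, a methoxy group or an amine at this carbon would give a lower or higher number than hydrogen remains open. Also open, from the compounds shown here alone, is whether this step holds on other rings.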